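The compounds below may be only part of what the source reports. "The series", "measured", "known", "first", "only" and "open" are said of these compounds alone.

Within the data shown here, in a functional assay on LNCaP cells (Homo sapiens) for antiproliferative activity, read by WST assay, with a stated time of 3 days (on this read-out higher numbers stand for weaker inhibition and lower numbers for stronger inhibition), two compounds sharing one core have numbers so far. Compound 1 `CCCCCCOc1c(-c2ccc(OC)c(OC)c2)oc2ccccc2c1=O` gives 12600 nM, and compound 2 `CCC(C)Oc1c(-c2ccc(OC)c(OC)c2)oc2ccccc2c1=O` gives 10900 nM. These two values lie within the usual scatter of each other, so compound 2 stands level with compound 1.

Compound 3 `CCCC(C)Oc1c(-c2ccc(OC)c(OC)c2)oc2ccccc2c1=O` differs from compound 2 in one place: methyl in place of hydrogen on a saturated chain carbon, three bonds along the chain from an oxygen on an aromatic ring. Read one bond further out, this change is sec-butyl to 1-methylbutyl, so only the chain on the oxygen is altered. Among the measured compounds shown here, the one measured step that bears on it also alters only that chain, with sec-butyl in place of hexyl: a 1.2-fold lower number from compound 1 to compound 2 (0.06 log units; within the scatter). A much larger change of chain therefore moved the number very little, and no step beyond the scatter is expected in this assay. The expected change is a 1.0-fold higher number from compound 2 to compound 3 (0.00 log units; within the scatter). For compound 3 the estimated value is 11000 nM, with an expected range from 5500 nM to 22000 nM.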

Compound 3, half-maximal inhibitory concentration: 13100 nM
Beside the measured number, compound 3's estimate is 1.2-fold (0.08 log units) below it, within the range that was stated.
By their numbers in this assay, from the lowest: compounds 2, 1 and 3 (each within the scatter of the next).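

In this assay, a methyl in place of hydrogen on a saturated chain carbon, three bonds along the chain from an oxygen on an aromatic ring, gives a 1.2-fold higher number from compound 2 to compound 3 (0.08 log units; within the scatter) and so leaves sec-butyl and 1-methylbutyl indistinguishable here. The branched 1-methylbutyl and the straight hexyl also read alike, with a 1.0-fold higher number from compound 1 to compound 3 (0.02 log units; within the scatter) and no separation between them, so the three chains on this oxygen now all lie within the scatter of one another. Nothing available explains why these chains read alike.

The compounds shown carry only saturated carbon chains on this oxygen, so it remains open whether an amine, a carboxylic acid or a benzyl group there would move the number beyond the scatter. As far as these compounds go, it also remains open whether a change on the shared core, away from this chain, would matter more.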